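The source may hold more compounds than are shown below. What is called first, only, known or untested is meant among the compounds shown, and "the series" means these compounds.

Measured so far in an assay on isolated protein for inhibition of Retinaldehyde dehydrogenase 3 (Homo sapiens), tested at 5 uM; a lower number here means less inhibition, a higher number more inhibition at the concentration tested (going by the name of the read-out):
compound 1, `CC(Sc1nc2c(cnn2C)c(=O)n1-c1ccccc1)c1ccncc1`: 45%
compound 2, `CC(Sc1nc2c(cnn2C)c(=O)n1-c1ccc(CN)cc1)c1ccccc1`: 56%

Within this pair compound 2 holds the higher of the two numbers in this assay; compound 1 is its only neighbour and sits lower by a margin beyond the usual scatter. Among the compounds with values here, no pair of measured compounds differs in a single place, so no step size has been observed.

Compound 3, `CNCc1ccc(-n2c(SC(C)c3ccccc3)nc3c(cnn3C)c2=O)cc1`, is still to be measured in this assay. Set against compound 2 the change is methyl in place of hydrogen on an amine nitrogen. Nothing in the present set speaks to this change, so the expectation rests on the value of compound 2 alone. The expected step, a number 3 percentage points lower from compound 2 to compound 3 (within the scatter), is taken to lie within the scatter, with no direction preferred. Compound 3 is estimated at 53%, with a range from 36% to 68%.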

Compound 3, a percentage reported as inhibition, at one concentration (the size of the read-out at that concentration, not a potency): 57%
Compound 3: middle estimate off by 4 percentage points, on the low side; the measured number falls inside the stated range.
By their numbers in this assay, from the lowest: compound 1; then compounds 2 and 3 (each within the scatter of the next).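

In this assay, within the data shown here, methyl in place of hydrogen on the amine nitrogen gives a number 1 percentage points higher from compound 2 to compound 3 (within the scatter), the first step that can be read at a single place. The 4-(aminomethyl)phenyl group therefore accepts this one added carbon on its nitrogen without a readable shift in inhibition at the tested concentration, so the hydrogen that leaves is not needed to hold this level in the pair. No supporting data shown here explain this result.

Still open, from the compounds shown here alone, is whether the same level holds with a dimethylamino group, an ethylamino group or an acetamide on the same carbon, or with a carboxylic acid in place of the amine. The contribution of the aminomethyl group itself also remains unread, since compound 1 differs from compound 2 in more than one place.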